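Bromo to Iodo Exchange across Three Measured Compounds

The source may hold more compounds than are shown below. What is called first, only, known or untested is meant among the compounds shown, and "the series" means these compounds.

All three measured compounds were run in an ADME assay on the whole organism with Oryza sativa as the target, tested at 10 uM; on this read-out higher numbers stand for a weaker effect at the one concentration tested and lower numbers for a stronger effect. Measured so far:

compound 1, `C[C@H](NC(=O)Nc1ccccc1Br)c1ccccc1`, gives 102%
compound 2, `C[C@@H](NC(=O)Nc1cccc(Br)c1)c1ccccc1`, gives 99%
compound 3, `C[C@H](NC(=O)Nc1ccccc1I)c1ccccc1`, gives 98%

Compound 1 and compound 3 share a core and differ in one place: iodo in place of bromo on an aromatic carbon. The step that this change made is a number 4 percentage points lower from compound 1 to compound 3 (within the scatter), so the two numbers are not separated here.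

Compound 2 is built from the same atoms as compound 1, joined differently; the difference between the two cores is not broken down here. Its value sits close to both compound 1 and compound 3, and none of the three numbers stands apart from the others by more than the usual scatter, so no order among them can be drawn from these data.

Compound 4, `C[C@@H](NC(=O)Nc1cccc(I)c1)c1ccccc1`, is not yet measured. It differs from compound 2 by iodo in place of bromo on an aromatic carbon. The place is not the same as in the step from compound 1 to compound 3, where the exchange sits ortho to a large group rather than meta to it, so the two changes are the same kind of change, not the same change.

Among the compounds with values here, the expectation for compound 4 rests on the one measured example of this kind of change: the step from compound 2 to compound 4 is expected to be a number 3 percentage points lower from compound 2 to compound 4 (within the scatter), beside a number 4 percentage points lower from compound 1 to compound 3 (within the scatter). Compound 4 is thus expected to give about 96%, with a range from 86% to 105% in which most repeats are expected to fall.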

Compound 4, a percentage reported as activity, at one concentration (the size of the read-out at that concentration, not a potency): 73%
Estimate against measurement, compound 4: 23 percentage points above; the whole stated range lies above it.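

In this assay, iodo in place of bromo on an aromatic carbon, meta to a large group, gives a number 26 percentage points lower from compound 2 to compound 4 (beyond the scatter), so on this core the exchange goes with a stronger effect at the one concentration tested. The size of the step does not carry over from one core to the other, and a step read on one core gives no safe estimate for the other: the same change on two cores in this assay, a number 4 percentage points lower (within the scatter) from compound 1 to compound 3 and a number 26 percentage points lower (beyond the scatter) from compound 2 to compound 4, 22 percentage points apart, beyond the scatter of two such steps

Within the data shown here, with only one matched pair on each core, these numbers do not show which feature of the cores sets the size of the step, and they give no rule for how the exchange would behave on any further core.

The compounds shown leave open whether the larger step is particular to iodo or would also appear with another group in the same place, such as chloro, methyl, trifluoromethyl, methoxy, an amine or a carboxylic acid. Also open, going by these compounds, is whether the gap between the two cores would hold at other concentrations, as each number here is a single read-out at one concentration and not a potency.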